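The source may report more compounds than this note shows. Statements on the series, on what has been measured and on what is new or still open speak of the compounds shown alone.

Measured so far:
Compound 1, `CCCCCCCCCCCCCCCCCC(=O)N[C@@H](CCSC)C(=O)Nc1ccn([C@H]2O[C@@H](CO)[C@H](O)[C@H]2O)c(=O)n1`: 803 nM
Compound 2, `CCCCCCCCCCCCCCCCCC(=O)N[C@@H](CCCNC(=N)N)C(=O)Nc1ccn([C@H]2O[C@@H](CO)[C@H](O)[C@H]2O)c(=O)n1`: 1700 nM
Compound 3, `CCCCCCCCCCCCCC(=O)N[C@@H](CCCNC(=N)N)C(=O)Nc1ccn([C@H]2O[C@@H](CO)[C@H](O)[C@H]2O)c(=O)n1`: 405 nM

All three were tested in a functional assay on HL-60 cells (Homo sapiens) for cytotoxicity, read by MTT assay, with a stated time of 48 h; on this read-out higher numbers stand for weaker inhibition and lower numbers for stronger inhibition. Compound 3 and compound 1 give numbers that lie within the scatter of each other, so nothing separates them on this read-out.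

Compound 4, `CCCCCCCCCCCCCC(=O)N[C@@H](CCSC)C(=O)Nc1ccn([C@H]2O[C@@H](CO)[C@H](O)[C@H]2O)c(=O)n1`, has not yet been measured in this assay. It differs from compound 3 by a group of 2 heavy atoms (1 carbon, 1 sulfur; no ring) in place of a group of 5 heavy atoms (2 carbon, 3 nitrogen; no ring), on a saturated chain carbon, three bonds along the chain from an amide-type nitrogen and a carbonyl carbon. The same change has been measured once already, from compound 2 to compound 1, and there it gave a 2.1-fold lower number from compound 2 to compound 1 (0.33 log units; beyond the scatter); the place of the change is the same in both pairs. The two cores, that of compound 2 and that of compound 3, differ by hydrogen in place of butyl on a saturated chain carbon, ten or more bonds along the chain from a carbonyl carbon, and on its own that change gave a 4.2-fold lower number from compound 2 to compound 3 (0.62 log units; beyond the scatter).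

The expectation is that compound 4 repeats the earlier step, an estimated 2.0-fold lower number from compound 3 to compound 4 (0.31 log units; beyond the scatter), resting on the number for compound 3, 405 nM, and on the step of a 2.1-fold lower number from compound 2 to compound 1 (0.33 log units; beyond the scatter). Compound 4 is therefore expected to come in near 200 nM, with a likely span from 80 nM to 500 nM.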

Compound 4, half-maximal inhibitory concentration: 272 nM
For compound 4 the middle estimate is 1.4-fold (0.13 log units) below the measured one, and the stated range covers the measured number.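

In this assay, putting methylsulfanyl in place of the group of 5 heavy atoms (2 carbon, 3 nitrogen) gives a 1.5-fold lower number from compound 3 to compound 4 (0.17 log units; within the scatter), and the gap to the same change on the longer-chain core is small: the same change on two cores in this assay, a 2.1-fold lower number (0.33 log units; beyond the scatter) from compound 2 to compound 1 and a 1.5-fold lower number (0.17 log units; within the scatter) from compound 3 to compound 4, 1.4-fold (0.15 log units) apart, within the scatter of two such steps Putting hydrogen in place of butyl on the long chain gives a 3.0-fold lower number from compound 1 to compound 4 (0.47 log units; beyond the scatter), and this change also carries over between the two cores with little difference: the same change on two cores in this assay, a 4.2-fold lower number (0.62 log units; beyond the scatter) from compound 2 to compound 3 and a 3.0-fold lower number (0.47 log units; beyond the scatter) from compound 1 to compound 4, 1.4-fold (0.15 log units) apart, within the scatter of two such steps Within this set of four compounds, each change therefore gives a similar step on both cores, but two pairs cannot show that this would hold on any other core, and the step from the side-chain swap on the shorter-chain core is not on its own distinguishable from scatter.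

The compounds shown leave open how an amine or a carboxylic acid in the place of methylsulfanyl would compare. They also leave open whether a still shorter chain, such as a decanoyl chain, would continue the trend seen with removing butyl.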